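Bromo series: trifluoromethyl in place of fluoro

The source may report more compounds than this note shows. Statements on the series, on what has been measured and on what is new or still open speak of the compounds shown alone.

Compound 3 `NC(=O)c1c(NC(=O)c2ccccc2Br)sc2c1CCN(C(=S)Nc1ccccc1F)C2` gives only a limit in a functional assay on MKN-74 cells (Homo sapiens) for antiproliferative activity, with a stated time of 24 h (on this read-out lower numbers stand for stronger inhibition and higher numbers for weaker inhibition), namely > 50000 nM. Two numbers anchor the series: compound 1 `NC(=O)c1c(NC(=O)c2ccccc2Cl)sc2c1CCN(C(=S)Nc1ccccc1F)C2` gives 12600 nM, and compound 2 `NC(=O)c1c(NC(=O)c2ccccc2Cl)sc2c1CCN(C(=S)Nc1ccccc1C(F)(F)F)C2` gives 1870 nM. Compound 4 `NC(=O)c1c(NC(=O)c2ccccc2Br)sc2c1CCN(C(=S)Nc1ccccc1C(F)(F)F)C2` is not yet measured; it differs from compound 3 by trifluoromethyl in place of fluoro on an aromatic carbon. The same change has been measured once, as a 6.7-fold lower number from compound 1 to compound 2 (0.83 log units; beyond the scatter). Exchanging chloro for bromo gave an at least 3.9-fold higher number from compound 1 to compound 3 (0.59 log units; beyond the scatter), a step that ends at the limit (the limit of > 50000 nM in this assay, at which 1 of the 3 values shown sits). Carrying the first step over, the expected step is an at least 4.1-fold lower number from compound 3 to compound 4 (0.61 log units; beyond the scatter), towards a lower number, though a start known only as a limit leaves the outcome loosely bounded. Compound 4 is estimated at 12000 nM, with a range from 4000 nM to 50000 nM.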

Compound 4, half-maximal inhibitory concentration: 24300 nM
Compound 4: the middle estimate sits 2.0-fold (0.31 log units) below what was measured; low and high end bracket the measured number.
By their numbers in this assay, from the lowest: compound 2; then compounds 1 and 4 (each within the scatter of the next). At a limit, above all of these: compound 3.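

In this assay, trifluoromethyl in place of fluoro also gives a lower number on the bromo side, an at least 2.0-fold lower number from compound 3 to compound 4 (0.31 log units; beyond the scatter), so the direction of this change now holds with both chloro and bromo. Bromo in place of chloro, with trifluoromethyl present, gives a 13-fold higher number from compound 2 to compound 4 (1.11 log units; beyond the scatter), and this step ends on a measured number. Whether either change differs in size between its two settings stays unresolved: the same change on two cores in this assay, a 6.7-fold lower number (0.83 log units; beyond the scatter) from compound 1 to compound 2 and an at least 2.0-fold lower number (0.31 log units; beyond the scatter) from compound 3 to compound 4; the limit leaves it open whether they differ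

Open, from the compounds shown here alone, is how an amine or a carboxylic acid in place of trifluoromethyl on this aromatic carbon would read. Also open, going by these compounds, is whether iodo in place of bromo would move the number further in the same direction.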